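Fluoro added to the dimethylphenyl arm of compound 3

The source may hold more compounds than are shown below. What is called first, only, known or untested is meant among the compounds shown, and "the series" means these compounds.

Going by the values given here, compound 3 `Cc1cc(C)cc(-c2c(-c3ccc(F)cc3)nc(C(F)(F)F)n2CC[C@@H](O)C[C@@H](O)CC(=O)O)c1` gives 38 nM in an assay on microsomes from liver for inhibition of 3-hydroxy-3-methylglutaryl-coenzyme A reductase (Rattus norvegicus) (on this read-out higher numbers stand for weaker inhibition and lower numbers for stronger inhibition), the lowest of the three numbers so far. Compound 1 `O=C(O)C[C@H](O)C[C@H](O)CCn1c(C(F)(F)F)nc(-c2ccc(F)cc2)c1-c1cccc(Cl)c1` gives 41 nM, and the step of a 1.1-fold lower number from compound 1 to compound 3 (0.03 log units; within the scatter) lies within the scatter, so compound 3 and compound 1 cannot be ordered. Compound 2 `COc1cccc(-c2c(-c3ccc(F)cc3)nc(C(F)(F)F)n2CC[C@@H](O)C[C@@H](O)CC(=O)O)c1` gives 135 nM, and the step of a 3.6-fold lower number from compound 2 to compound 3 (0.55 log units; beyond the scatter) is beyond the scatter, as is a 3.3-fold higher number from compound 1 to compound 2 (0.52 log units; beyond the scatter).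

Compound 4 `Cc1cc(-c2c(-c3ccc(F)cc3)nc(C(F)(F)F)n2CC[C@@H](O)C[C@@H](O)CC(=O)O)cc(C)c1F` differs from compound 3 by fluoro in place of hydrogen on an aromatic carbon. Among the compounds with values here, no measured step adds a fluoro to this ring; the steps at hand change the groups on the aryl arm, and even the largest of them, a 3.6-fold lower number from compound 2 to compound 3 (0.55 log units; beyond the scatter), is modest. Two of the three aryl variants, compound 1 and compound 3, sit within the scatter of each other in this assay, which suggests this arm tolerates changes of this size without large movement in the number. Adding a single fluorine here is therefore expected to give at most a small step, a 1.1-fold lower number from compound 3 to compound 4 (0.04 log units; within the scatter), with no direction that can be called beyond the scatter.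

Compound 4 is estimated at 35 nM in this assay, in the range 15 nM to 90 nM.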

Compound 4, half-maximal inhibitory concentration: 31 nM
Compound 4: middle estimate off by 1.1-fold (0.05 log units), on the high side; the measured number falls inside the stated range.
By their numbers in this assay, from the lowest: compounds 4, 3 and 1 (each within the scatter of the next); then compound 2.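

Working notes on the aryl arm: in this assay the aromatic carbon ortho to two methyl groups and para to a large group accepts a fluoro with no readable effect (a 1.2-fold lower number from compound 3 to compound 4 (0.09 log units; within the scatter)), the first information on substitution at this carbon. The 4-fluoro-3,5-dimethylphenyl arm keeps the gap that 3,5-dimethylphenyl already held over the 3-methoxyphenyl arm (a 4.4-fold lower number from compound 2 to compound 4 (0.64 log units; beyond the scatter)), and it cannot be separated from the 3-chlorophenyl arm (a 1.3-fold lower number from compound 1 to compound 4 (0.12 log units; within the scatter)). So a single fluorine leaves the standing of this arm in the series unchanged, and the dimethylphenyl pattern remains open to substitution at this carbon, at least for an atom of this size. No measurement bears on why the fluoro leaves the number within the scatter.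

Still open, on these data alone, is whether this carbon accepts anything beyond a single atom, such as a hydroxyl, an amine or a carboxylic acid, in place of the fluoro. It is also open whether a fluoro on the 3-chlorophenyl arm of compound 1 would behave as it does here, since the one step shown comes from the dimethylphenyl arm alone.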